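Adding chloro to the phenyl group: series working notes

The compounds below may be only part of what the source reports. "The series", "measured", "known", "first", "only" and "open" are said of these compounds alone.

Measured in a functional assay; on this read-out higher numbers stand for weaker inhibition and lower numbers for stronger inhibition:
compound 1 `CC(C)=CCOc1ccc2c(c1)OC(c1ccccc1)CC2=O`: 6070 nM
compound 2 `CC(C)=CCOc1ccc2c(c1)OC(c1cccc(Cl)c1)CC2=O`: 6300 nM
compound 3 `CC(C)=CCOc1cc(O)c2c(c1)OC(c1ccc(Cl)cc1)CC2=O`: 7020 nM

Compound 1 and compound 2 differ by chloro in place of hydrogen on an aromatic carbon, and the step is a 1.0-fold higher number from compound 1 to compound 2 (0.02 log units; within the scatter). The difference between the core of compound 1 and the core of compound 3 is not broken down here. Compound 4 `CC(C)=CCOc1cc(O)c2c(c1)OC(c1ccc(Cl)cc1Cl)CC2=O` is not yet measured; it differs from compound 3 by chloro in place of hydrogen on an aromatic carbon. This is the same kind of change as that from compound 1 to compound 2, but the surroundings differ: in compound 2 the chloro sits meta to a large group, whereas in compound 4 it sits ortho to a large group and meta to a chloro group. The expected step is a 1.0-fold lower number from compound 3 to compound 4 (0.00 log units; within the scatter), resting on the within-scatter step a 1.0-fold higher number from compound 1 to compound 2 (0.02 log units; within the scatter). For compound 4 the estimated value in this assay is 7000 nM, expected to fall between 3000 nM and 16000 nM.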

Compound 4, half-maximal inhibitory concentration: 3340 nM
Beside the measured number, compound 4's estimate is 2.1-fold (0.32 log units) above it, within the range that was stated.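

In this assay, chloro in place of hydrogen on the core of compound 3 gives a 2.1-fold lower number from compound 3 to compound 4 (0.32 log units; beyond the scatter), whereas the same change on the core of compound 1 gives a 1.0-fold higher number from compound 1 to compound 2 (0.02 log units; within the scatter). Set together, the two steps cannot be told apart: the same change on two cores in this assay, a 1.0-fold higher number (0.02 log units; within the scatter) from compound 1 to compound 2 and a 2.1-fold lower number (0.32 log units; beyond the scatter) from compound 3 to compound 4, 2.2-fold (0.34 log units) apart, within the scatter of two such steps. Going by these compounds alone, this shows no measured dependence of the change on the core, but it does not establish reliable transfer, since each core offers only one pair and the chloro sits in different surroundings in each.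

Open, on these data alone, is whether a nitrile or an amine at the same place would give a step of similar size. Also open, as far as these compounds go, is whether the step would hold on a core bearing a longer chain.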